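A few compounds are considered here, and "the series" means these few. Any claim that something is new, unique, unknown or untested is made for them only; others in the source may bear on it.

The study compares three measured compounds and one still awaiting its number. Compound 1 `COc1ccc(Br)cc1-c1nc(N)nc(N)n1` and compound 2 `Nc1nc(N)nc(-c2cc(Br)ccc2Cl)n1` share one core, while compound 3 `Cc1c(N(C)C)c(=O)n(C)c(=O)n1-c1ccc(Cl)cc1` is built on a different one; the difference between the two cores is not broken down here. Compound 4 `COc1ccc(-n2c(C)c(N(C)C)c(=O)n(C)c2=O)cc1` derives from compound 3.

In a physicochemical assay for lipophilicity (a higher number here means a more lipophilic compound, a lower number a more polar compound), compound 1 gives 1.53, compound 2 gives 2.04 and compound 3 gives 2.32. Compound 3 shows the highest of the three numbers, and against compound 2 its number is within the scatter, whereas against compound 1 the gap is beyond it.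

The change that separates compound 2 from compound 1 is methoxy in place of chloro on an aromatic carbon and produced a number 0.51 log units lower from compound 2 to compound 1 (beyond the scatter). Compound 4 differs from compound 3 by methoxy in place of chloro on an aromatic carbon. The surroundings are not identical: in compound 1 the methoxy sits ortho to a group of 8 heavy atoms and para to a bromo group, while in compound 4 it sits para to a large group. It is therefore the same kind of change rather than the same one, made on different cores.

Resting on the step seen between compound 2 and compound 1, she expects a drop of similar size from compound 3, namely a number 0.51 log units lower from compound 3 to compound 4 (beyond the scatter). For compound 4 she estimates 1.81 in this assay, with a likely span from 1.4 to 2.2.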

Compound 4, partition coefficient: 1.96
Compound 4: middle estimate off by 0.15 log units, on the low side, within the range that was stated.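

In this assay, the replacement of chloro by methoxy on an aromatic carbon gave a number 0.36 log units lower from compound 3 to compound 4 (beyond the scatter) on the core of compound 3, and the same kind of change gave a number 0.51 log units lower from compound 2 to compound 1 (beyond the scatter) on the core of compound 1, so across these two pairs the step runs in the same direction and lies beyond the scatter each time. Among the compounds shown here, this supports carrying the direction of the change between these two cores, but it rests on only two pairs whose surroundings differ, and it shows neither that the step would hold on a further core nor that its size can be treated as fixed. Nothing presented here bears on what lies behind the step on either core, so the two pairs describe the change without accounting for it.

The compounds shown leave open how an ethoxy group, an amine or a carboxylic acid on that same aromatic carbon would compare with chloro and methoxy in this assay on either core. They also leave open whether methoxy in place of chloro would give a step in the same direction with the bromo group absent from the shared core of compound 1 and compound 2.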